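Aryl amine variation on the shared core

This account rests on a few compounds, and the source may have more. Where it says the series, first, only, none or still open, it means among the compounds named here.

Three compounds with the shared core have numbers in a functional assay, with a stated time of 6 min; on this read-out lower numbers stand for stronger inhibition and higher numbers for weaker inhibition. Compound 1 `COc1ccc(NCn2nc(-c3ccc4c(c3)OCCO4)oc2=S)cc1` gives 5830 nM. Compound 2 `Fc1ccccc1NCn1nc(-c2ccc3c(c2)OCCO3)oc1=S` gives 6390 nM. Compound 3 `S=c1oc(-c2ccc3c(c2)OCCO3)nn1CNc1ccc(Cl)cc1` gives 7270 nM. Compound 3 sits at the upper end of the three numbers, yet its steps to the other two are within the scatter: a 1.2-fold higher number from compound 1 to compound 3 (0.10 log units; within the scatter) and a 1.1-fold higher number from compound 2 to compound 3 (0.06 log units; within the scatter). The remaining step, a 1.1-fold higher number from compound 1 to compound 2 (0.04 log units; within the scatter), is also within the scatter, so three different aryl groups on the amine nitrogen have so far moved nothing beyond the scatter.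

Compound 4 `O=[N+]([O-])c1ccccc1NCn1nc(-c2ccc3c(c2)OCCO3)oc1=S` is not yet measured. It differs from compound 3 in one place: 2-nitrophenyl in place of 4-chlorophenyl on an amine nitrogen. The measured steps that bear on this are the aryl exchanges on that same nitrogen, a 1.1-fold higher number from compound 1 to compound 2 (0.04 log units; within the scatter) and a 1.1-fold higher number from compound 2 to compound 3 (0.06 log units; within the scatter), both within the scatter, and a 1.2-fold higher number from compound 1 to compound 3 (0.10 log units; within the scatter) likewise. A nitro group has not appeared among the measured compounds, so this change is not covered directly. Every aryl change so far stayed within the scatter. The expected step in this assay is accordingly none beyond the scatter, a 1.1-fold lower number from compound 3 to compound 4 (0.05 log units; within the scatter). Compound 4 is estimated at 6500 nM, with a range from 3000 nM to 14000 nM.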

Compound 4, half-maximal inhibitory concentration: 10900 nM
Compound 4: the middle estimate sits 1.7-fold (0.22 log units) below what was measured; the measured number falls inside the stated range.
By their numbers in this assay, from the lowest: compounds 1, 2, 3 and 4 (each within the scatter of the next).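

In this assay, the aryl exchanges on the amine nitrogen now include 2-nitrophenyl, a group with 9 heavy atoms and 2 hydrogen-bond acceptors, where 4-chlorophenyl has 7 heavy atoms and no hydrogen-bond acceptors, and all three new steps stay within the scatter (a 1.5-fold higher number from compound 3 to compound 4 (0.18 log units; within the scatter); a 1.7-fold higher number from compound 2 to compound 4 (0.23 log units; within the scatter); a 1.9-fold higher number from compound 1 to compound 4 (0.27 log units; within the scatter)). The exchange of nitro for fluoro on an aromatic carbon adds a direct comparison of two groups carried on the same aryl ring, and it also moves nothing beyond the scatter, so across the four aryl groups shown, this position has not yet separated any pair of compounds. No measurement here bears on why these compounds fall so close together.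

As far as these compounds go, whether any change at this position can move the number beyond the scatter remains open, as the four compounds all carry a substituted phenyl ring on the amine nitrogen. A carboxylic acid or a dimethylamino group on that ring, a cyclohexyl group in its place, or a methyl group on the amine nitrogen would test this position more widely.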